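A few compounds are considered here, and "the series" means these few. Any claim that something is new, unique, unknown or untested is made for them only; others in the source may bear on it.

Compound 1 `CCCCNc1oc2c(C)ncc(CO)c2c1Nc1ccccn1` is examined in a functional assay on HEK293 cells for agonist activity at Toll-like receptor 8 (Homo sapiens), read by reporter gene assay (on this read-out higher numbers stand for an effect only at larger amounts of compound and lower numbers for an effect already at smaller amounts), where compound 1 gives 9380 nM. Within the data shown here, its only measured neighbour, compound 2 `Cc1ncc(CO)c2c(Nc3ccccn3)c(NCc3ccccc3)oc12`, gives 4910 nM in this assay, and the step of a 1.9-fold lower number from compound 1 to compound 2 (0.28 log units; within the scatter) leaves the two within the scatter of each other. Compound 3 `Cc1ncc(CO)c2c(Nc3ccccn3)c(NC3CCCCC3)oc12` differs from compound 1 by cyclohexyl in place of butyl on a nitrogen on an aromatic ring. Among the measured compounds shown here, no measured step touches this change; the single recorded step, a 1.9-fold lower number from compound 1 to compound 2 (0.28 log units; within the scatter), alters another part of the molecule and is itself small, so nothing beyond the scatter is expected here. Compound 3 is therefore estimated at 6500 nM in this assay, within 2000 nM to 20000 nM, which means an expected step of a 1.4-fold lower number from compound 1 to compound 3 (0.16 log units; within the scatter).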

Compound 3, half-maximal effective concentration: 6930 nM
For compound 3 the middle estimate is 1.1-fold (0.03 log units) below the measured one; measured number inside the range.
By their numbers in this assay, from the lowest: compounds 2, 3 and 1 (each within the scatter of the next).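

In this assay, the nitrogen on the aromatic ring now carries a six-membered non-aromatic ring of carbon only, and the number stays within the scatter of both open-chain and benzyl compounds: a 1.4-fold lower number from compound 1 to compound 3 (0.13 log units; within the scatter) and a 1.4-fold higher number from compound 2 to compound 3 (0.15 log units; within the scatter). Butyl, benzyl and cyclohexyl therefore cannot be told apart at this position. Nothing available bears on a reason for this result. Open remains whether a longer chain such as octyl, or a chain ending in an amine, would move the number beyond the scatter.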